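Chain Length at the Amide Side of Compound 2

The source may report more compounds than this note shows. Statements on the series, on what has been measured and on what is new or still open speak of the compounds shown alone.

compound 1, `COC(=O)c1c(O)c2ccccc2n(C)c1=O`: 18.4%
compound 2, `Cn1c(=O)c(C(=O)NCCN)c(O)c2ccccc21`: 37.1%
compound 3, `NCCNC(=O)c1c(O)c2ccccc2n(-c2ccccc2)c1=O`: 7.9%

Among the three compounds measured in a functional assay, with a stated time of 60 min, tested at 0.5 mM (on this read-out lower numbers stand for a weaker effect and higher numbers for a stronger effect at the one concentration tested), compound 2 stands highest. Its nearest neighbour is compound 1, reached by the step of a number 18.7 percentage points higher from compound 1 to compound 2 (beyond the scatter), and the furthest is compound 3, reached by the step of a number 29.2 percentage points lower from compound 2 to compound 3 (beyond the scatter); both steps lie beyond the usual scatter.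

Compound 4, `Cn1c(=O)c(C(=O)NCCCCCCN)c(O)c2ccccc21`, has not been measured. It differs from compound 2 in one place: 4-aminobutyl in place of amino on a saturated chain carbon, two bonds along the chain from an amide-type nitrogen. Neither measured step exchanges one aminoalkyl chain for a longer one. For the measured compounds named here, the step of a number 18.7 percentage points higher from compound 1 to compound 2 (beyond the scatter) replaces methoxy by (2-aminoethyl)amino on the carbonyl carbon, and the step of a number 29.2 percentage points lower from compound 2 to compound 3 (beyond the scatter) replaces methyl by phenyl on the aromatic nitrogen, so the data hold no precedent for the change from compound 2 to compound 4, and the side chain that carries the change is kept in both. On that basis no step beyond the scatter in this assay is expected in either direction, with a wide range to cover the lack of a direct precedent.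

The step from compound 2 to compound 4 is estimated as a number 2.1 percentage points lower from compound 2 to compound 4 (within the scatter). Compound 4 is therefore expected to give about 35%, with a range from 15% to 55%.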

Compound 4, a percentage reported as activity, at one concentration (the size of the read-out at that concentration, not a potency): 21.9%
For compound 4 the middle estimate is 13.1 percentage points above the measured one; the range from low to high includes it.
By their numbers in this assay, from the lowest: compound 3; then compounds 1 and 4 (each within the scatter of the next); then compound 2.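

The change from 2-aminoethyl to 6-aminohexyl comes out as a number 15.2 percentage points lower from compound 2 to compound 4 (beyond the scatter) in this assay, the first read on chain length in this series. The earlier steps had shown that the read-out responds to placing the (2-aminoethyl)amino group on the carbonyl carbon and to the group on the aromatic nitrogen, whereas this step shows that it also responds to the length of that side chain, even with the shared core unchanged. The terminal amine is present at both chain lengths, so its presence alone does not hold the level of compound 2 , and nothing available here explains the lower number at the longer chain.

With only two chain lengths compared, the compounds shown cannot tell whether a 3-aminopropyl or 4-aminobutyl chain would follow a gradual decline or whether the read-out falls off at some particular length, nor what a still longer chain would give. They also leave open how a hydroxyl or carboxylic acid at the chain end would compare with the amine, and whether lengthening the chain would have a similar effect with phenyl on the aromatic nitrogen.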